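The source may hold more compounds than are shown below. What is called first, only, known or untested is meant among the compounds shown, and "the series" means these compounds.

Measured in a physicochemical assay for lipophilicity, read by HPLC, at pH 7.5; a lower number here means a more polar compound, a higher number a more lipophilic compound:
- compound 1 `CC[C@@H](Nc1c(C#N)c(-c2ccc(-c3cccc(C)c3F)cc2)nc2cnccc12)C(N)=O`: 3
- compound 2 `CCOc1ccccc1-c1ccc(-c2nc3cnccc3c(N[C@H](CC)C(=O)NS(=O)(=O)C3CC3)c2C#N)cc1`: 2.3
- compound 3 `CC[C@@H](Nc1c(C#N)c(-c2ccc(-c3cccc(CO)c3)cc2)nc2cnccc12)C(N)=O`: 2

Among these three, compound 2 sits within the usual scatter of compound 3, and its number lies below that of compound 1 by more than the scatter. The step under consideration leads to compound 4 `CCOc1ccccc1-c1ccc(-c2nc3cnccc3c(NC(COC)C(N)=O)c2C#N)cc1`, and the change is a group of 7 heavy atoms (4 carbon, 1 nitrogen, 2 oxygen; no ring) in place of a group of 12 heavy atoms (7 carbon, 1 nitrogen, 3 oxygen, 1 sulfur; one three-membered non-aromatic ring of carbon only), on a nitrogen on an aromatic ring. The entering group is 1-carbamoyl-2-methoxyethyl, placed on a nitrogen on an aromatic ring.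

Among the compounds with values here, no measured step tests this exchange directly. The only one available, a number 1.00 log units lower from compound 1 to compound 3 (beyond the scatter), places 3-(hydroxymethyl)phenyl in place of 2-fluoro-3-methylphenyl on an aromatic carbon, so it gives only a sense of scale. The values offer a weak guide to direction. Compound 4 carries a carbamoyl group and no sulfur, and so does compound 1. Compound 1 reads 3, while compound 3, also a carbamoyl compound, reads 2. Those two numbers span a range whose middle lies above the number of compound 2, so a modest rise, smaller than the measured step, is expected in this assay. The expected change is a number 0.50 log units higher from compound 2 to compound 4 (beyond the scatter). For compound 4 the estimated value is 2.8, with an expected range from 2.2 to 3.4.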

Compound 4, distribution coefficient: 2.8
Beside the measured number, compound 4's estimate shows no gap at the digits printed, and the stated range covers the measured number.
By their numbers in this assay, from the lowest: compounds 3 and 2 (each within the scatter of the next); then compounds 4 and 1 (each within the scatter of the next).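

In this assay, placing 1-carbamoyl-2-methoxyethyl on a nitrogen on an aromatic ring, in place of the group of 12 heavy atoms with its sulfur and its three-membered carbon ring, gives a number 0.50 log units higher from compound 2 to compound 4 (beyond the scatter). This is the first step shown at this position, as the only earlier one, a number 1.00 log units lower from compound 1 to compound 3 (beyond the scatter), is an exchange on an aromatic carbon, and it shows that a change on this nitrogen can also move the number beyond the scatter. No measurement shown accounts for the rise, and the single step exchanges the sulfur, the ring, a hydrogen-bond acceptor and a defined stereocentre all at once.

The compounds shown leave open which of these differences carries the step, as no compound here alters only one of them. They also leave open how this assay would read with a carboxylic acid in place of the carbamoyl group, or with a longer carbon chain in place of the methoxy-bearing arm of 1-carbamoyl-2-methoxyethyl, on the same nitrogen.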